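Bromo for Methyl on a Shared Core: Expected Step

The compounds below may be only part of what the source reports. "The series", "measured", "known", "first", "only" and "open" are said of these compounds alone.

Measured compounds in a functional assay on Ehrlich cells (Mus musculus) for cytotoxicity, read by trypan blue exclusion, with a stated time of 48 h; on this read-out lower numbers stand for stronger inhibition and higher numbers for weaker inhibition:
- compound 1, `Cc1ccc(-c2csc(NC(=O)COc3ccccc3)n2)cc1`, gives 49800 nM
- compound 2, `O=C(COc1ccccc1)Nc1nc(-c2ccc(Br)cc2)cs1`, gives 37100 nM
- compound 3, `Cc1ccc(OCC(=O)Nc2nc(-c3ccc(C)cc3)cs2)cc1`, gives 45100 nM

All three numbers sit close together, and none of the three compounds can be called the most or the least potent on this evidence. The pair compound 1 and compound 2 differ only in one place, described as bromo in place of methyl on an aromatic carbon, and this produced a 1.3-fold lower number from compound 1 to compound 2 (0.13 log units; within the scatter). Compound 3 differs from compound 1 in another place, described as methyl in place of hydrogen on an aromatic carbon, with a 1.1-fold lower number from compound 1 to compound 3 (0.04 log units; within the scatter); this is how the core of compound 3 differs from the core of compound 1.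

Compound 4, `Cc1ccc(OCC(=O)Nc2nc(-c3ccc(Br)cc3)cs2)cc1`, has not yet been measured in this assay. It differs from compound 3 as bromo in place of methyl on an aromatic carbon. The place of this change is described in the same words as the place of the change from compound 1 to compound 2, so it is the same change, now made on the core of compound 3.

The expected step from compound 3 to compound 4 in this assay is a 1.3-fold lower number from compound 3 to compound 4 (0.11 log units; within the scatter), set beside the measured 1.3-fold lower number from compound 1 to compound 2 (0.13 log units; within the scatter); this expectation rests on the closeness of compound 1 and compound 3, shown by a 1.1-fold lower number from compound 1 to compound 3 (0.04 log units; within the scatter), and on the single observed instance of the change. Compound 4 is therefore expected to give about 35000 nM in this assay, most plausibly between 15000 nM and 80000 nM.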

Compound 4, half-maximal inhibitory concentration: 55300 nM
Compound 4: middle estimate off by 1.6-fold (0.20 log units), on the low side; the range from low to high includes it.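

In this assay, the bromo for methyl change on the core of compound 3 gives a 1.2-fold higher number from compound 3 to compound 4 (0.09 log units; within the scatter), and this step agrees with its earlier instance: the same change on two cores in this assay, a 1.3-fold lower number (0.13 log units; within the scatter) from compound 1 to compound 2 and a 1.2-fold higher number (0.09 log units; within the scatter) from compound 3 to compound 4, 1.6-fold (0.22 log units) apart, within the scatter of two such steps The methyl in place of hydrogen change, read on the core of compound 2, gives a 1.5-fold higher number from compound 2 to compound 4 (0.17 log units; within the scatter), and it likewise agrees with its earlier instance: the same change on two cores in this assay, a 1.1-fold lower number (0.04 log units; within the scatter) from compound 1 to compound 3 and a 1.5-fold higher number (0.17 log units; within the scatter) from compound 2 to compound 4, 1.6-fold (0.22 log units) apart, within the scatter of two such steps This shows that each change stayed within the scatter on both cores, but it does not show a real effect that carries from one core to another, as each change has only two instances and no direction can be assigned to either.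

The compounds shown carry only methyl, bromo or hydrogen at the changed places, leaving open whether an amine or a carboxylic acid there, or a longer chain in the link joining the two parts of the molecule, would move the number beyond the scatter. They also leave open whether these small steps would hold on other kinds of cells or at another exposure time, as the account rests on this assay alone.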